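Swapping phenyl for pyridin-2-yl at the amide carbonyl

The source may hold more compounds than are shown below. What is called first, only, known or untested is meant among the compounds shown, and "the series" means these compounds.

Compound 1 `COc1ccc(-c2cnc(NC(=O)c3ccc(C)cc3)n2C)cc1` gives > 100000 nM in a toxicity assay on THP-1 cells (Homo sapiens) for inhibition (a higher number here means that more compound is tolerated, a lower number that less compound is tolerated), which is a limit of the assay rather than a number. Compound 2 `COc1ccc(-c2cnc(NC(=O)c3ccccc3)n2C)cc1` gives > 100000 nM, again a limit.

Going by the values given here, the only step measured so far, a step that the two limits leave unreadable from compound 1 to compound 2, cannot be sized, since both of its values sit at the limit of > 100000 nM in this assay, at which 2 of the 2 values shown sit. All that can be said is that removing the methyl did not push tolerance down far enough to yield a number.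

Compound 3 `COc1ccc(-c2cnc(NC(=O)c3ccccn3)n2C)cc1` differs from compound 2 by pyridin-2-yl in place of phenyl on a carbonyl carbon. Among the compounds with values here, no measured step involves a pyridin-2-yl group, so the one step on record only bears on it indirectly: it shows that the shared core with an unsubstituted phenyl amide is tolerated at least up to the limit. With nothing pointing either way, compound 3 is expected to stay at or near that same limit, and the expected step that the limit leaves unreadable from compound 2 to compound 3 is taken as none beyond the scatter. The estimate for compound 3 is therefore 150000 nM, with a range from 50000 nM to 500000 nM, most likely reported once more as a limit.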

Compound 3, half-maximal cytotoxic concentration: > 100000 nM
Compound 3 gave a limit, no number; the forecaster's own chance of this, stated with the estimate: 85%; the middle value is on the limit's open side.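

Compound 3 also gives a limit rather than a number, so no step among compound 1, compound 2 and compound 3 can be read: the limit of > 100000 nM in this assay, at which 3 of the 3 values shown sit.

The compounds shown leave open what concentration of each is half-maximally cytotoxic in this assay, and so whether 4-methylphenyl, phenyl or pyridin-2-yl on a carbonyl carbon makes any difference there.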